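Three Measured Compounds and One Expected Value

A few compounds are considered here, and "the series" means these few. Any claim that something is new, unique, unknown or untested is made for them only; others in the source may bear on it.

Three compounds were tested in a functional assay on JM1 cells (Homo sapiens) for cytotoxicity; on this read-out lower numbers stand for higher toxicity in this test and higher numbers for lower toxicity in this test. Compound 1 `Cc1cn([C@H]2C=C[C@@H](CNC(=O)CC3(C)CC(C)(O)CO3)O2)c(=O)[nH]c1=O` reaches only a limit of this assay, > 500000 nM; > 500000 nM (2 entries). Compound 2 `CSCOC1(C)COC(C)(CC(=O)NC[C@@H]2C=C[C@H](n3cc(C)c(=O)[nH]c3=O)O2)C1` likewise stops at a limit of this assay, > 1000000 nM. Compound 3 `CC1=CN([C@H]2C[C@H](O)[C@@H](COC(=O)C[C@@]3(C)C[C@@](C)(O)CO3)O2)C(=O)NC1` is also reported as a limit of this assay, > 500000 nM. On the numbers shown, compound 3 therefore stands where the others do: its own value is a limit, one further value is a limit, and one further entry carries no single number. The two thresholds that appear are the limit of > 1000000 nM in this assay, at which 1 of the 3 values shown sits, and (the limit of > 500000 nM in this assay, at which 1 of the 3 values shown sits). Among the measured compounds shown here, no step between two measured compounds that differ in one place is available.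

Compound 4 `Cc1cn([C@H]2C[C@H](O)[C@@H](COC(=O)C[C@@]3(C)C[C@@](C)(O)CO3)O2)c(=O)[nH]c1=O` has not yet been measured. It differs from compound 3 in one respect: a group of 9 heavy atoms (5 carbon, 2 nitrogen, 2 oxygen; one six-membered aromatic ring with 2 hetero atoms) in place of a group of 8 heavy atoms (5 carbon, 2 nitrogen, 1 oxygen; one six-membered non-aromatic ring with 2 hetero atoms), on a saturated ring carbon. Since compound 3 sits at a limit with > 500000 nM, one expects no shift beyond the usual scatter in this assay. The step of a number no higher from compound 3 to compound 4 (the limit leaves the size open) is accordingly estimated as essentially flat. Compound 4 is expected to give about 500000 nM, within a range from 200000 nM to 1000000 nM, and most probably to be reported once more as a limit.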

Compound 4, half-maximal cytotoxic concentration: > 1000000 nM
Compound 4 gave a limit, no number; the forecaster's own chance of this, stated with the estimate: 85%; middle value at least 2.0-fold (0.30 log units) away from the limit.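

Among the compounds shown here, compound 3 and compound 4 both stop at a limit of this assay, so no step between them can be read. The compounds shown leave open at what concentration any of them would reach half-maximal cytotoxicity, and whether the exchange of the ring group separating compound 3 from compound 4 alters it.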